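The source may hold more compounds than are shown below. What is called first, only, known or untested is meant among the compounds shown, and "the series" means these compounds.

Measured compounds in a functional assay on PC-3 cells (Homo sapiens) for inhibition, with a stated time of 72 h; a higher number here means a weaker inhibitor, a lower number a stronger inhibitor:
compound 1, `COc1ccc(NC(=O)Nc2nc(Sc3c[nH]c4ccccc34)cc(N3CCN(Cc4ccccc4)CC3)n2)cc1`: 16700 nM
compound 2, `Cc1cc(Cl)ccc1NC(=O)Nc1nc(NC2CC2)cc(Sc2c[nH]c3ccccc23)n1`: 11100 nM
compound 3, `COc1ccc(NC(=O)Nc2nc(Nc3cc(OC)cc(OC)c3)cc(Sc3c[nH]c4ccccc34)n2)cc1`: 15100 nM

Compound 1 carries the highest of the three numbers in this assay, but its gap to compound 3 and its gap to compound 2 both lie within the scatter, so the three stand together and no order among them can be read. Among the measured compounds shown here, no two of the measured compounds differ in only one place, so no measured step between them is available.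

Compound 4, `Cc1ccc(C)c(NC(=O)Nc2nc(Sc3c[nH]c4ccccc34)cc(N3CCN(Cc4ccccc4)CC3)n2)c1`, is not yet measured. It differs from compound 1 in one place: 2,5-dimethylphenyl in place of 4-methoxyphenyl on an amide-type nitrogen. The shared core and the remaining substituents of compound 1 are kept unchanged. For the measured compounds named here, with no measured step of this kind to rest on, the expectation is that the exchange leaves the number of compound 1 roughly where it stands. The step of a 1.2-fold lower number from compound 1 to compound 4 (0.08 log units; within the scatter) is therefore expected to be none beyond the scatter in either direction. Compound 4 is estimated at 14000 nM, with a range from 5000 nM to 40000 nM. Going by the values given here, the range is kept wide because compound 1 gives 16700 nM as the only anchor, and the size of an aryl exchange on the urea nitrogen has no measured step to set it.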

Compound 4, half-maximal inhibitory concentration: 17300 nM
Compound 4: the middle estimate sits 1.2-fold (0.09 log units) below what was measured; measured number inside the range.
By their numbers in this assay, from the lowest: compounds 2, 3, 1 and 4 (each within the scatter of the next).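

In this assay, among the compounds shown here, 2,5-dimethylphenyl in place of 4-methoxyphenyl on the amide-type nitrogen gives a 1.0-fold higher number from compound 1 to compound 4 (0.02 log units; within the scatter) and, as the first single-place step, shows that this pair cannot be told apart at this position. The exchange removes the oxygen and the hydrogen-bond acceptor of the leaving group while keeping the same count of heavy atoms and a six-membered aromatic ring of carbon only, so for these two aryl groups, with the rest of compound 1 unchanged, the loss of that acceptor leaves no readable difference in the number. No measurement is at hand that bears on why the two compounds stand together.

For the compounds shown here, the step covers only two substituted phenyl groups, so it remains open whether a different kind of group on this nitrogen, such as a pyridine ring, a cyclohexyl group or a phenyl carrying a carboxylic acid, would give a step beyond the scatter. Also open, from the compounds shown here alone, is whether the same aryl exchange would read alike with a cyclopropylamino group on the shared core in place of the substituent that compound 1 carries there.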